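This account rests on a few compounds, and the source may have more. Where it says the series, first, only, none or still open, it means among the compounds named here.

Measured compounds: compound 1 `COc1cc(-c2nnc3n2NC(c2ccco2)C(C(=O)c2ccccc2F)S3)cc(OC)c1OC` and compound 2 `COc1cc(-c2nnc3n2NC(c2ccco2)C(C(=O)c2ccc(C)cc2)S3)cc(OC)c1OC`. In a functional assay on HepG2 cells (Homo sapiens) for cytotoxicity, read by MTT assay, with a stated time of 48 h (a higher number here means a weaker inhibitor, a lower number a stronger inhibitor), compound 1 gives only a limit, > 100000 nM. In this assay compound 2 gives 17400 nM, which is the only number shown. The other value shown, that of compound 1, is a limit (the limit of > 100000 nM in this assay, at which 1 of the 2 values shown sits). Compound 3 `COc1cc(-c2nnc3n2NC(c2ccco2)C(C(=O)c2cccc4ccccc24)S3)cc(OC)c1OC` differs from compound 2 by naphthalen-1-yl in place of 4-methylphenyl on a carbonyl carbon. Going by the values given here, the one measured step, an at least 5.7-fold lower number from compound 1 to compound 2 (0.75 log units; beyond the scatter), concerns the same carbonyl substituent but does not involve naphthalen-1-yl, so in this assay no step beyond the scatter is expected, a 1.2-fold lower number from compound 2 to compound 3 (0.06 log units; within the scatter). Compound 3 is therefore estimated at 15000 nM, between 4000 nM and 60000 nM.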

Compound 3, half-maximal inhibitory concentration: 33900 nM
The estimate for compound 3 lay 2.3-fold (0.35 log units) below the measured number; the measured number falls inside the stated range.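

In this assay, a 1.9-fold higher number from compound 2 to compound 3 (0.29 log units; within the scatter), so the second six-membered aromatic ring of naphthalen-1-yl leaves the number within the scatter of that with 4-methylphenyl on this carbonyl carbon. Against 2-fluorophenyl, an at least 2.9-fold lower number from compound 1 to compound 3 (0.46 log units; beyond the scatter), so a second group on the carbonyl carbon now stands apart from 2-fluorophenyl. The value of compound 1 is a limit and not a number: the limit of > 100000 nM in this assay, at which 1 of the 3 values shown sits.

On these data alone, how a pyridin-3-yl group, a plain methyl group or a carboxylic acid on this carbonyl carbon would read stays open. So does whether fluorine itself sets compound 1 apart.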